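The source may report more compounds than this note shows. Statements on the series, on what has been measured and on what is new or still open speak of the compounds shown alone.

Measured compounds:
- compound 1 `Cc1nc2c(OCCc3ccccc3)cccn2c1N`, 56%
- compound 2 `Cc1nc2c(OCc3ccccc3)nccn2c1N`, 79%

Within the data shown here, of these two compounds compound 2 stands highest in a functional assay on the whole organism with Rattus norvegicus as the target, at a dose of 40 mg/kg by the intraperitoneal route; on this read-out higher numbers stand for more inhibition at the one dose given (going by the name of the read-out) and lower numbers for less inhibition; compound 1 lies lower by a gap beyond the usual scatter, and no single-point step joins the pair. Compound 3 `CCNc1c(C)nc2c(OCc3ccccc3)nccn12` differs from compound 2 by ethyl in place of hydrogen on a nitrogen on an aromatic ring. Among the measured compounds shown here, no measured step of this kind exists here, so the size of the change can only be expected: a small step, probably downward, likely not beyond the scatter, is estimated as a number 13 percentage points lower from compound 2 to compound 3 (beyond the scatter). Compound 3 is therefore expected to give about 66%, within a range from 38% to 88%.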

Compound 3, a percentage reported as inhibition, in the whole organism at one dose (the size of the read-out at that dose, not a potency): 48%
Compound 3: middle estimate off by 18 percentage points, on the high side, within the range that was stated.
By their numbers in this assay, from the lowest: compounds 3 and 1 (each within the scatter of the next); then compound 2.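

Ethyl in place of hydrogen on a nitrogen on an aromatic ring gives the first single-place comparison in this assay, and the step is large: a number 31 percentage points lower from compound 2 to compound 3 (beyond the scatter). At this position, then, the change from amino to ethylamino does not leave the inhibition of compound 2 intact. Nothing at hand accounts for this loss. On these data alone, whether methyl, a longer chain such as propyl, or an acetyl group on this nitrogen would bring a step of similar size remains open. So does whether ethyl would act alike on the core of compound 1.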